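Working notes: from 2-hydroxyphenyl to 4-hydroxyphenyl

The compounds below may be only part of what the source reports. "The series", "measured", "known", "first", "only" and "open" are said of these compounds alone.

- compound 1 `CCCCCCCCCCCCCCNC(=O)[C@H](CO)/N=C/c1ccccc1OC`: 79200 nM
- compound 2 `CCCCCCCCCCCCCCNC(=O)[C@H](CO)/N=C/c1ccccc1O`: 80800 nM

The read-out here is an ADME assay on HEK293 cells (Homo sapiens) for cytotoxicity; on this read-out higher numbers stand for weaker inhibition and lower numbers for stronger inhibition. In this assay compound 2 gives 80800 nM and stands level with compound 1, within the scatter. The next structure is compound 3 `CCCCCCCCCCCCCCNC(=O)[C@H](CO)/N=C/c1ccc(O)cc1`, still unmeasured, and the change is 4-hydroxyphenyl in place of 2-hydroxyphenyl on a carbon with a double bond to nitrogen. Among the compounds with values here, only one measured step bears on this, and only indirectly: a 1.0-fold higher number from compound 1 to compound 2 (0.01 log units; within the scatter), with hydrogen in place of methyl on an oxygen on an aromatic ring. Within the data shown here, no measured step moves the hydroxy group itself, so direct evidence is lacking. Among the measured compounds shown here, the one step available stayed within the scatter, so none beyond it is expected here. The expected step is a 1.1-fold lower number from compound 2 to compound 3 (0.03 log units; within the scatter). Compound 3 is estimated at 75000 nM, with an expected range of 40000 nM to 125000 nM.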

Compound 3, half-maximal inhibitory concentration: 71700 nM
The estimate for compound 3 lay 1.0-fold (0.02 log units) above the measured number; low and high end bracket the measured number.
By their numbers in this assay, from the lowest: compounds 3, 1 and 2 (each within the scatter of the next).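

Within the data shown here, the first direct reading at this position comes from moving the hydroxy group: in this assay, 4-hydroxyphenyl in place of 2-hydroxyphenyl on a carbon with a double bond to nitrogen gives a 1.1-fold lower number from compound 2 to compound 3 (0.05 log units; within the scatter) and so leaves the read-out within the scatter. Replacing 2-methoxyphenyl with 4-hydroxyphenyl at the same place gives a 1.1-fold lower number from compound 1 to compound 3 (0.04 log units; within the scatter) and likewise stays within the scatter, so the three aromatic groups shown do not separate on this read-out. Nothing available explains this lack of separation.

As far as these compounds go, whether an amine or a carboxylic acid on the aromatic ring would keep the number in this range remains open. Also open, from the compounds shown here alone, is whether a shorter chain in place of the long amide chain would shift the read-out beyond the scatter.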